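Hydroxy addition on the styryl ring of a dienone series

This account rests on a few compounds, and the source may have more. Where it says the series, first, only, none or still open, it means among the compounds named here.

The series shares the core of compound 1 `O=C(/C=C(O)/C=C/c1cccc(O)c1)c1cc(Cl)ccc1O`, a chlorinated analogue, which in an assay on isolated protein for inhibition of Alpha glucosidase (Homo sapiens), with stated times of 5 min and 15 min (a higher number here means a weaker inhibitor, a lower number a stronger inhibitor), gives compound 1 a reading of 36400 nM. The dechlorinated parent, compound 2 `O=C(/C=C(O)/C=C/c1cccc(O)c1)c1ccccc1O`, has no number to stand on: in this assay compound 2 is recorded as "not determined" (no result reported). Going by the values given here, with no step between two measured compounds available, the position of compound 2 on the scale is unknown, and the single number of compound 1 is the only anchor.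

Compound 3 `O=C(/C=C(O)/C=C/c1ccc(O)c(O)c1)c1ccccc1O` differs from compound 2 by hydroxy in place of hydrogen on an aromatic carbon. Among the compounds with values here, as no measured pair shows this change, any expectation rests on the one reading of compound 1 and on the change itself; a gain of some size toward a lower value is the working assumption, though a step within the scatter cannot be excluded.

For compound 3 the value in this assay is estimated at 15000 nM, with the expected range running from 3000 nM to 80000 nM.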

Compound 3, half-maximal inhibitory concentration: 14300 nM
For compound 3 the middle estimate is 1.0-fold (0.02 log units) above the measured one; the range from low to high includes it.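

In this assay compound 3 gives 14300 nM while compound 2 has no single number, so no step can be read from compound 2 to compound 3. The compounds shown leave open what hydroxy in place of hydrogen does to the reading on this core. No supporting evidence bears on this result.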